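This account rests on a few compounds, and the source may have more. Where it says the series, first, only, none or still open, it means among the compounds named here.

Compound 1 `N=c1sc2cc(OC(F)(F)F)ccc2n1Cc1ccccc1`: > 10 mg/kg
Compound 2 `COC(=O)Cn1c(=N)sc2cc(OC(F)(F)F)ccc21`: > 10 mg/kg

In a functional assay on the whole organism with Rattus norvegicus as the target (a lower number here means that less compound is needed, a higher number that more compound is needed for the effect), compound 1 gives > 10 mg/kg, which is a limit and not a number. Compound 2 gives > 10 mg/kg, and this too is only a limit. Both compounds therefore share (the limit of > 10 mg/kg in this assay, at which 2 of the 2 values shown sit), so the standing of compound 2 is known only through that limit.

Compound 3 `N=c1sc2cc(OC(F)(F)F)ccc2n1CC(=O)O` has not yet been measured. It differs from compound 2 by hydrogen in place of methyl on an oxygen next to a carbonyl group, turning methoxycarbonyl into carboxy. Among the compounds with values here, the only measured step, a step that the two limits leave unreadable from compound 1 to compound 2, introduced the methoxycarbonyl group, but it gives no size to carry over. No clear direction can therefore be expected in this assay, and another limit is likely. The expected change is a step that the limit leaves unreadable from compound 2 to compound 3. If a number is obtained, compound 3 is estimated at 20 mg/kg, within an expected range of 8 mg/kg to 50 mg/kg.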

Compound 3, dose for half-maximal effect: > 10 mg/kg
Compound 3: no number, only a limit (the forecaster's own chance of this, stated with the estimate: 75%); the middle value is on the limit's open side.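

Compound 3 in this assay gives > 10 mg/kg and this too is a limit. Within the data shown here, no step among compound 1, compound 2 and compound 3 can therefore be read: the limit of > 10 mg/kg in this assay, at which 3 of the 3 values shown sit. The compounds shown leave open what dose of any of the three gives the half-maximal effect.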